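Paw edema series: side-chain swap from compound 2 to compound 3

This account rests on a few compounds, and the source may have more. Where it says the series, first, only, none or still open, it means among the compounds named here.

Measured compounds:
compound 1 `CCOC(=O)C1=C(C)NC(C)=C(C(=O)OCC)C1c1ccc(OCC(=O)Nc2ccc(C)cc2)cc1`, 55.1%
compound 2 `CCOC(=O)C1=C(C)NC(C)=C(C(=O)OCC)C1c1ccc(OCc2nnc(S)o2)cc1`, 54.5%

In a functional assay on the whole organism (strain Wistar) for inhibition, with Rattus norvegicus as the target, read by paw edema, with stated times of 30 min and 1 h, at a dose of 20 mg/kg (on this read-out higher numbers stand for more inhibition at the one dose given (going by the name of the read-out) and lower numbers for less inhibition), compound 2 stands lowest of the two numbers, with compound 1 the nearest, and that step a number 0.6 percentage points lower from compound 1 to compound 2 (within the scatter) is within the scatter. Compound 3 `CCOC(=O)C1=C(C)NC(C)=C(C(=O)OCC)C1c1ccc(OCC(=O)n2nc(C)cc2C)cc1` differs from compound 2 by (3,5-dimethyl-1H-pyrazol-1-yl)carbonyl in place of 5-sulfanyl-1,3,4-oxadiazol-2-yl on a saturated chain carbon bound to an oxygen on an aromatic ring. Among the compounds with values here, the only step that bears on this place is a number 0.6 percentage points lower from compound 1 to compound 2 (within the scatter), where exchanging the group at the same place changed nothing beyond the scatter. No step beyond the scatter is therefore expected for compound 3, an estimated a number 0.5 percentage points lower from compound 2 to compound 3 (within the scatter). Compound 3 is expected to give 54%, between 42% and 66%.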

Compound 3, a percentage reported as inhibition, in the whole organism at one dose (the size of the read-out at that dose, not a potency): 32.7%
For compound 3 the middle estimate is 21.3 percentage points above the measured one; measured number below the stated range.
By their numbers in this assay, from the lowest: compound 3; then compounds 2 and 1 (each within the scatter of the next).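

In this assay this position is not indifferent to its group: (3,5-dimethyl-1H-pyrazol-1-yl)carbonyl in place of 5-sulfanyl-1,3,4-oxadiazol-2-yl gives a number 21.8 percentage points lower from compound 2 to compound 3 (beyond the scatter). With the carbonyl kept, 3,5-dimethyl-1H-pyrazol-1-yl in place of (4-methylphenyl)amino gives a number 22.4 percentage points lower from compound 1 to compound 3 (beyond the scatter), so the group on the carbonyl carbon alone separates these compounds. Nothing available accounts for this loss of inhibition.

From the compounds shown here alone, whether the loss follows the two methyl groups or the pyrazole ring itself remains open, and a plain pyrazol-1-yl carbonyl would separate the two. Also open, going by these compounds, is how a carboxylic acid or a simple amine would read at this place.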